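Trimming the ketone side chain in a positive allosteric modulator series

The source may report more compounds than this note shows. Statements on the series, on what has been measured and on what is new or still open speak of the compounds shown alone.

Measured so far:
compound 1, `COc1cc(C(=O)O)ccc1OCCCCOc1ccc(C(=O)CC(C)(C)C)c(O)c1C`: 47 nM
compound 2, `Cc1c(OCCCCOc2ccc(F)c(C(=O)O)c2)ccc(C(=O)CC2CCCC2)c1O`: 699 nM

Among the compounds with values here, in an assay on HEK293 cells for positive allosteric modulation of metabotropic glutamate receptor 2 (Rattus norvegicus), read by thallium flux, with a stated time of 2.5 min (a higher number here means that more compound is needed for the effect, a lower number that less compound is needed), compound 1 gives 47 nM, the lowest of the two numbers known here. Within the data shown here, compound 2 gives 699 nM, a far higher number, and the two differ in more than one place, so their values show only that compound 1 needs much less compound for the effect.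

Compound 3, `COc1cc(C(=O)O)ccc1OCCCCOc1ccc(C(C)=O)c(O)c1C`, has not yet been measured. It differs from compound 1 in one respect: hydrogen in place of tert-butyl on a saturated chain carbon bound to a carbonyl carbon. Among the measured compounds shown here, in this series the saturated chain on the carbonyl is the only part of the molecule that changes here, and the data hold no step that isolates its contribution. Shortening it to acetyl is expected to cost potency: the step of a 13-fold higher number from compound 1 to compound 3 (1.11 log units; beyond the scatter) is estimated to be beyond the scatter, in the direction of a higher number. Compound 3 is thus expected to give about 600 nM, within a range from 120 nM to 3500 nM.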

Compound 3, half-maximal effective concentration: 161 nM
Estimate against measurement, compound 3: 3.7-fold (0.57 log units) above; the range from low to high includes it.
By their numbers in this assay, from the lowest: compound 1; then compound 3; then compound 2.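

Within the data shown here, this is the first change in this assay that touches one place only, so the tert-butyl on a saturated chain carbon bound to a carbonyl carbon can now be judged by itself. Replacing it with hydrogen, which turns neopentylcarbonyl into acetyl, brings a 3.4-fold higher number from compound 1 to compound 3 (0.53 log units; beyond the scatter) and lies beyond the scatter, so the tert-butyl adds to potency, yet compound 3 still gives 161 nM without it. Nothing available here explains why the larger group gives the lower number.

Among these compounds, compound 2 differs from both of the others in more than one place, so no steps to it can be read. From the compounds shown here alone, whether an isopropyl group or a longer chain at this carbon would match the tert-butyl, or give a number between those of compound 1 and compound 3, stays open.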